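The source may hold more compounds than are shown below. What is called first, only, known or untested is meant among the compounds shown, and "the series" means these compounds.

Measured in an ADME assay on microsomes from liver (Homo sapiens) for metabolic stability, read by LC-MS, using NADPH, tested at 5 uM; a higher number here means that the compound lasts longer, a lower number that the compound disappears faster:

compound 1, `Cc1cc(S(=O)(=O)/N=C(\N)n2nccc2-c2ccccc2)c(SCc2ccccc2)cc1Cl`: 0.0772 h
compound 2, `Cc1cc(-c2ccccc2)n(/C(N)=N/S(=O)(=O)c2cc(C)c(Cl)cc2SCc2ccccc2)n1`: 0.0938 h
compound 3, `Cc1cc(S(=O)(=O)/N=C(\N)n2nccc2-c2ccccc2)c(SCc2ccccc2C(F)(F)F)cc1Cl`: 0.15 h

Compound 2 differs from compound 1 by methyl in place of hydrogen on an aromatic carbon and this gave a 1.2-fold higher number from compound 1 to compound 2 (0.08 log units; within the scatter). Compound 3 differs from compound 1 by trifluoromethyl in place of hydrogen on an aromatic carbon and this gave a 1.9-fold higher number from compound 1 to compound 3 (0.29 log units; within the scatter). All three half-lives in this assay sit within the scatter of one another, so no order among them is claimed.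

Compound 4, `Cc1cc(-c2ccccc2)n(/C(N)=N/S(=O)(=O)c2cc(C)c(Cl)cc2SCc2ccccc2C(F)(F)F)n1`, is not yet measured. It differs from compound 3 by methyl in place of hydrogen on an aromatic carbon. This is the same change as the one from compound 1 to compound 2, and it occurs twice among the compounds shown; the two cores differ by trifluoromethyl in place of hydrogen on an aromatic carbon. Among the measured compounds shown here, the only precedent for the change is the step of a 1.2-fold higher number from compound 1 to compound 2 (0.08 log units; within the scatter), which stayed within the scatter. On that basis the step from compound 3 to compound 4 in this assay is expected to be a 1.2-fold higher number from compound 3 to compound 4 (0.08 log units; within the scatter). Compound 4 is accordingly estimated at 0.18 h, most likely between 0.09 h and 0.36 h.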

Compound 4, half-life: 0.306 h
Compound 4: the middle estimate sits 1.7-fold (0.23 log units) below what was measured; the measured number falls inside the stated range.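

In this assay, the change from 5-phenyl-1H-pyrazol-1-yl to 3-methyl-5-phenyl-1H-pyrazol-1-yl gives a 2.0-fold higher number from compound 3 to compound 4 (0.31 log units; beyond the scatter), and this step does not differ from its precedent on the core of compound 1: the same change on two cores in this assay, a 1.2-fold higher number (0.08 log units; within the scatter) from compound 1 to compound 2 and a 2.0-fold higher number (0.31 log units; beyond the scatter) from compound 3 to compound 4, 1.7-fold (0.23 log units) apart, within the scatter of two such steps
Read the other way, trifluoromethyl in place of hydrogen gives a 3.3-fold higher number from compound 2 to compound 4 (0.51 log units; beyond the scatter), and this step likewise does not differ from its precedent: the same change on two cores in this assay, a 1.9-fold higher number (0.29 log units; within the scatter) from compound 1 to compound 3 and a 3.3-fold higher number (0.51 log units; beyond the scatter) from compound 2 to compound 4, 1.7-fold (0.23 log units) apart, within the scatter of two such steps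
Among the compounds shown here, both changes therefore carry between these two cores without a detectable difference in step size, but each rests on only two pairs of compounds, which does not establish that the steps are equal or that they would hold on any other core.

Still open, on these data alone, is whether a longer chain such as ethyl, or an amine, on the five-membered aromatic ring in place of the methyl would give a step of similar size in this assay. The same question stands for a carboxylic acid in place of the trifluoromethyl.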